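Aryl swap on a piperazine sulfonamide hydroxamate

A few compounds are considered here, and "the series" means these few. Any claim that something is new, unique, unknown or untested is made for them only; others in the source may bear on it.

Measured compounds:
Compound 1 `O=C(/C=C/c1cccc(S(=O)(=O)N2CCN(c3ccccn3)CC2)c1)NO` – in an assay for inhibition of histone deacetylase 4 (Homo sapiens), read by fluorescence, with a stated time of 3 h (on this read-out higher numbers stand for an effect only at larger amounts of compound and lower numbers for an effect already at smaller amounts), compound 1 gives "not determined" (no result reported)
Compound 2 `O=C(/C=C/c1nc2ccccc2o1)NO` – in this assay compound 2 gives 373 nM

Compound 1 stands without a number in this assay, so its position cannot be fixed from the data. Compound 3 `COc1ccc(N2CCN(S(=O)(=O)c3cccc(/C=C/C(=O)NO)c3)CC2)cc1` carries a single change from compound 1: 4-methoxyphenyl in place of pyridin-2-yl on an amine nitrogen in a ring. For the measured compounds named here, with no measured step for this change, the difference between compound 1 and compound 3 in this assay is expected to stay within the usual scatter, in no set direction. Compound 3 is expected to give about 500 nM, estimated between 100 nM and 3000 nM.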

Compound 3, concentration for half-maximal effect: 870 nM
For compound 3 the middle estimate is 1.7-fold (0.24 log units) below the measured one; the measured number falls inside the stated range.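

For the compounds shown here, compound 1 has no single number here, so no step from it to compound 3 can be read. The compounds shown leave open how pyridin-2-yl and 4-methoxyphenyl compare on the shared core, and no evidence bears on the result.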